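The source may report more compounds than this note shows. Statements on the series, on what has been measured and on what is new or still open speak of the compounds shown alone.

Compounds measured so far in an ADME assay on Vero cells (Chlorocebus sabaeus) for cytotoxicity, read by resazurin assay, with a stated time of 72 h; on this read-out lower numbers stand for higher toxicity in this test and higher numbers for lower toxicity in this test:

Compound 1 `O=C(/C=C/c1ccc([N+](=O)[O-])o1)c1ccc(-c2ccccc2)cc1`. In this assay compound 1 gives > 100000 nM, which is a limit of the assay rather than a number.
Compound 2 `COc1ccc(/C=C/C(=O)c2cccc(I)c2)cc1`. In this assay compound 2 gives > 100000 nM, again a limit.
Compound 3 `COc1ccc(/C=C/C(=O)c2cccc(Br)c2)cc1`. In this assay compound 3 gives > 100000 nM, again a limit.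

Compound 1 therefore stands where every value shown stands: at the limit (the limit of > 100000 nM in this assay, at which 3 of the 3 values shown sit), with nothing finer readable about it. For the measured compounds named here, the only step between two measured compounds that differ in one place, a step that the two limits leave unreadable from compound 2 to compound 3, is unreadable for the same reason, both of its ends being limits.

Compound 4 `O=C(/C=C/c1ccc([N+](=O)[O-])o1)c1ccc(I)cc1` differs from compound 1 in one place: iodo in place of phenyl on an aromatic carbon. Going by the values given here, no measured step swaps a phenyl for an iodo, so none bears on this change directly, and the one step that does exist gives no size at all. All three measured values sit at the limit (the limit of > 100000 nM in this assay, at which 3 of the 3 values shown sit), and compound 4 is expected to join them there, so the expected step of a number no higher from compound 1 to compound 4 (the limit leaves the size open) is none beyond the scatter. Compound 4 is estimated at 100000 nM, within a range from 40000 nM to 250000 nM.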

Compound 4, half-maximal cytotoxic concentration: > 100000 nM
Compound 4 gave a limit, no number; the forecaster's own chance of this, stated with the estimate: 75%; the middle value sits exactly at the limit.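

The change from compound 1 to compound 4, iodo in place of phenyl, gives no readable step, because both ends of it are limits rather than numbers: the limit of > 100000 nM in this assay, at which 4 of the 4 values shown sit. The compounds shown leave open how toxic any of them is in this assay, and whether the iodo and phenyl groups differ in this test at all.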